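Aryl swaps on the triazole nitrogen, all beyond the limit

The compounds below may be only part of what the source reports. "The series", "measured", "known", "first", "only" and "open" are said of these compounds alone.

Compound 1 `Cc1ccccc1-n1nncc1CN1C(=O)C2(C(C#N)=C(N)Oc3c2c2nc4ccccc4nc2c2ccccc32)c2ccccc21` gives > 50000 nM in an ADME assay on HUVEC cells (Homo sapiens) for antiproliferative activity, read by MTT assay, with a stated time of 48 h; on this read-out lower numbers stand for stronger inhibition and higher numbers for weaker inhibition.
Compound 2 `Cc1cccc(-n2nncc2CN2C(=O)C3(C(C#N)=C(N)Oc4c3c3nc5ccccc5nc3c3ccccc43)c3ccccc32)c1` gives > 50000 nM in this assay.
Compound 3 `N#CC1=C(N)Oc2c(c3nc4ccccc4nc3c3ccccc23)C12C(=O)N(Cc1cnnn1-c1ccc(Cl)cc1)c1ccccc12` gives > 50000 nM in this assay.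

Each of these three values is a limit of this assay and not a number, so compound 1 cannot be placed anywhere on a scale; it sits with the others at the limit of > 50000 nM in this assay, at which 3 of the 3 values shown sit. Within the data shown here, the three measured steps, a step that the two limits leave unreadable from compound 1 to compound 2, a step that the two limits leave unreadable from compound 1 to compound 3 and a step that the two limits leave unreadable from compound 2 to compound 3, are therefore unreadable in size and direction, and they say only that exchanging one aryl group for another on the aromatic nitrogen did not bring any compound into the readable range.

Compound 4 `N#CC1=C(N)Oc2c(c3nc4ccccc4nc3c3ccccc23)C12C(=O)N(Cc1cnnn1-c1ccccc1Cl)c1ccccc12` differs from compound 1 by chloro in place of methyl on an aromatic carbon. This is the same kind of exchange on the same aromatic nitrogen as in the measured steps, and none of them gave a readable change. The step from compound 1 to compound 4 in this assay is thus expected to stay unreadable as well, with compound 4 most likely again reported only as a limit.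

Compound 4 is estimated at 50000 nM in this assay, within 20000 nM to 120000 nM, which would mean a step of a number no higher from compound 1 to compound 4 (the limit leaves the size open) that is expected to be no more than scatter.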

Compound 4, half-maximal inhibitory concentration: > 50000 nM
Compound 4: a limit, no number (the forecaster's own chance of this, stated with the estimate: 85%); the middle value lies on the limit itself.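

Compound 4 is again only a limit, so its steps to compound 1, compound 2 and compound 3 cannot be read, and all four compounds sit together in this assay: the limit of > 50000 nM in this assay, at which 4 of the 4 values shown sit.

The compounds shown leave open how strongly any of them inhibits in this assay, and whether exchanging the aryl group changes that at all.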